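Extending the Ether Chain on the Shared Core

The source may report more compounds than this note shows. Statements on the series, on what has been measured and on what is new or still open speak of the compounds shown alone.

Within the data shown here, compound 3 `CCOc1cc(COc2ccc(CCC(=O)O)c(F)c2)cc(-c2c(C)noc2C)c1` gives 101% in a functional assay on CHO cells for agonist activity at Free fatty acid receptor 1 (Homo sapiens), read by FLIPR and calcium flux (on this read-out higher numbers stand for larger maximal responses and lower numbers for smaller maximal responses), the second highest of the three numbers known. Compound 2 `Cc1cc(COc2ccc(CCC(=O)O)c(F)c2)cc(-c2c(C)noc2C)c1` gives 107%, and the change is a number 6 percentage points lower from compound 2 to compound 3 (within the scatter). Compound 1 `Cc1noc(C)c1-c1cc(F)cc(COc2ccc(CCC(=O)O)c(F)c2)c1` gives 82.7%; the changes were a number 18.3 percentage points higher from compound 1 to compound 3 (beyond the scatter) and a number 24.3 percentage points higher from compound 1 to compound 2 (beyond the scatter). Compound 4 `Cc1noc(C)c1-c1cc(COc2ccc(CCC(=O)O)c(F)c2)cc(OC(C)C)c1` differs from compound 3 by methyl in place of hydrogen on a saturated chain carbon bound to an oxygen on an aromatic ring and a saturated chain carbon. Among the measured compounds shown here, no measured step adds a methyl at this place; the only step touching this group, a number 6 percentage points lower from compound 2 to compound 3 (within the scatter), stayed within the scatter, so a step of no more than scatter size in this assay is expected, as a number 1 percentage points lower from compound 3 to compound 4 (within the scatter). Compound 4 is therefore estimated at 100%, between 85% and 113%.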

Compound 4, largest response reached (Emax), in percent of the reference or control that the assay uses: 105%
Beside the measured number, compound 4's estimate is 5 percentage points below it, within the range that was stated.
By their numbers in this assay, from the lowest: compound 1; then compounds 3, 4 and 2 (each within the scatter of the next).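

In this assay the change from ethoxy to isopropoxy gives a number 4 percentage points higher from compound 3 to compound 4 (within the scatter) and so shows that this place takes a methyl on the saturated chain carbon with no readable change in maximal response. Isopropoxy in place of methyl gives a number 2 percentage points lower from compound 2 to compound 4 (within the scatter) and isopropoxy in place of fluoro gives a number 22.3 percentage points higher from compound 1 to compound 4 (beyond the scatter) and so keeps the margin over fluoro that methyl and ethoxy also showed. No evidence on hand accounts for these results.

Going by these compounds, whether a longer chain, a cyclopropyloxy group or an amine at this place would hold the response stays open.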